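The compounds below may be only part of what the source reports. "The series", "measured", "known", "first", "only" and "open" are said of these compounds alone.

Three compounds have so far been measured in a functional assay on PC-3 cells (Homo sapiens) for cytotoxicity, read by MTT assay, with a stated time of 72 h; a lower number here means a stronger inhibitor, a higher number a weaker inhibitor:
compound 1, `COc1ccc2nc(NC(=O)c3cn(-c4ccccc4)nc3-c3ccc(F)cc3)sc2c1`, which gives 12800 nM;
compound 2, `Cc1ccc2nc(NC(=O)c3cn(-c4ccccc4)nc3-c3ccc(F)cc3)sc2c1`, which gives 20500 nM;
compound 3, `COc1ccc2nc(NC(=O)c3cn(-c4ccccc4)nc3-c3ccc(Cl)cc3)sc2c1`, which gives 29300 nM.

Compound 2 differs from compound 1 by methyl in place of methoxy on an aromatic carbon, and that change produced a 1.6-fold higher number from compound 1 to compound 2 (0.20 log units; within the scatter). Compound 3 differs from compound 1 by chloro in place of fluoro on an aromatic carbon, a change that produced a 2.3-fold higher number from compound 1 to compound 3 (0.36 log units; beyond the scatter). Compound 4, `Cc1ccc2nc(NC(=O)c3cn(-c4ccccc4)nc3-c3ccc(Cl)cc3)sc2c1`, has not yet been tested in this assay. It differs from compound 3 by methyl in place of methoxy on an aromatic carbon, which is the same change as that between compound 1 and compound 2, now made on the core of compound 3. The step from compound 3 to compound 4 is expected to be a 1.5-fold higher number from compound 3 to compound 4 (0.19 log units; within the scatter), set beside a 1.6-fold higher number from compound 1 to compound 2 (0.20 log units; within the scatter), on which the expectation rests. Compound 4 is therefore estimated at 45000 nM, within a range from 22000 nM to 95000 nM.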

Compound 4, half-maximal inhibitory concentration: 14500 nM
The estimate for compound 4 lay 3.1-fold (0.49 log units) above the measured number; measured number below the stated range.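

In this assay, methyl in place of methoxy did not carry over from one core to the other, giving a 2.0-fold lower number from compound 3 to compound 4 (0.31 log units; beyond the scatter): the same change on two cores in this assay, a 1.6-fold higher number (0.20 log units; within the scatter) from compound 1 to compound 2 and a 2.0-fold lower number (0.31 log units; beyond the scatter) from compound 3 to compound 4, 3.2-fold (0.51 log units) apart, beyond the scatter of two such steps
Chloro in place of fluoro likewise did not carry over, giving a 1.4-fold lower number from compound 2 to compound 4 (0.15 log units; within the scatter): the same change on two cores in this assay, a 2.3-fold higher number (0.36 log units; beyond the scatter) from compound 1 to compound 3 and a 1.4-fold lower number (0.15 log units; within the scatter) from compound 2 to compound 4, 3.2-fold (0.51 log units) apart, beyond the scatter of two such steps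
This shows that, among these four compounds, the outcome of each change depends on the group present at the other place, but it does not explain that dependence or show how either change would behave on a further core.

The compounds shown leave open what an amine or a longer alkoxy chain in place of the methoxy would give in this assay. They also leave open what a nitrile in place of the halogen would give.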